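The source may hold more compounds than are shown below. What is called first, only, known or untested is meant among the compounds shown, and "the series" means these compounds.

The measured compounds in a functional assay on T-24 cells (Homo sapiens) for cytotoxicity, read by CCK-8 assay, with a stated time of 24 h; a lower number here means a stronger inhibitor, a higher number a weaker inhibitor:

compound 1, `C/C(=C\c1cc(-c2ccc(F)cc2)cs1)C(N)=O`, gives > 50000 nM, a limit of the assay.
compound 2, `C/C(=C\c1cc(-c2ccc(C#N)cc2)cs1)C(N)=O`, gives > 50000 nM, a limit of the assay.
compound 3, `C/C(=C\c1cc(-c2ccc(S(C)(=O)=O)cc2)cs1)C(N)=O`, gives > 50000 nM, a limit of the assay.

Compound 3 stands at the same limit as the other two compounds; none of the three gives a number, so compound 3 cannot be placed above or below either of them. The step to compound 4, `C/C(=C\c1cc(-c2ccc([N+](=O)[O-])cc2)cs1)C(N)=O`, changes the shared core of compound 3 in one place: nitro in place of methylsulfonyl on an aromatic carbon.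

Within the data shown here, three measured steps bear on this change, all of them exchanges of the group on the same aromatic carbon: a step that the two limits leave unreadable from compound 1 to compound 2, a step that the two limits leave unreadable from compound 1 to compound 3 and a step that the two limits leave unreadable from compound 2 to compound 3. None of them can be sized, because the limit of > 50000 nM in this assay, at which 3 of the 3 values shown sit, holds all three values at the limit. The earlier exchanges of this group between fluoro, cyano and methylsulfonyl have not carried any compound past the limit, and the nitro group in compound 4 is expected to behave likewise, so the step that the limit leaves unreadable from compound 3 to compound 4 is estimated to be no larger than the scatter. Compound 4 is therefore expected to give about 60000 nM in this assay, within a range from 15000 nM to 300000 nM, most likely again reported only as a limit.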

Compound 4, half-maximal inhibitory concentration: > 50000 nM
Compound 4: no number, only a limit; the forecaster's own chance of this, stated with the estimate: 85%; the middle value lies beyond the limit too.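

In this assay compound 4 gives > 50000 nM, a limit of the assay. The steps from compound 1, compound 2 and compound 3 to compound 4 therefore cannot be read: the limit of > 50000 nM in this assay, at which 4 of the 4 values shown sit. The compounds shown leave open whether any group on this aromatic carbon would give a measurable value in this assay.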